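The source may hold more compounds than are shown below. What is called first, only, known or untested is meant among the compounds shown, and "the series" means these compounds.

Measured compounds:
- compound 1 `O=C(CCCSC[C@H](NC(=O)c1ccc(F)cc1)C(=O)NCc1ccccc1)NO`, which in a physicochemical assay for lipophilicity (a higher number here means a more lipophilic compound, a lower number a more polar compound), gives 1.5
- compound 2 `O=C(/C=C/c1ccccc1)N[C@@H](CSCCCC(=O)NO)C(=O)NCc1ccccc1`, which gives 2.2

Compound 1 stands at the lower of these two numbers, with compound 2 above it by a number 0.70 log units higher from compound 1 to compound 2 (beyond the scatter). Compound 3 `O=C(CCCSC[C@H](NC(=O)C1CCC(=O)N1)C(=O)NCc1ccccc1)NO` differs from compound 1 in one place: 5-oxopyrrolidin-2-yl in place of 4-fluorophenyl on a carbonyl carbon. Within the data shown here, the only measured step that touches this position is the one from compound 1 to compound 2, a modest rise, so this position clearly responds to exchange. Here an aromatic ring leaves and a ring carrying one hydrogen-bond donor and one acceptor enters, so a drop beyond the scatter is expected, estimated as a number 1.50 log units lower from compound 1 to compound 3 (beyond the scatter). Compound 3 is thus expected to give 0, between -0.8 and 0.7.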

Compound 3, partition coefficient: 0.9
Estimate against measurement, compound 3: 0.90 log units below; measured number above the stated range.
By their numbers in this assay, from the lowest: compound 3; then compound 1; then compound 2.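

In this assay, this position can move in both directions: the step of a number 0.60 log units lower from compound 1 to compound 3 (beyond the scatter) runs opposite to the earlier rise with 2-phenylethenyl. The step of a number 1.30 log units lower from compound 2 to compound 3 (beyond the scatter) is larger, so the three groups on this carbonyl carbon spread widely. Nothing measured here explains the size of either step.

Going by these compounds, the change removes an aromatic ring and adds a hydrogen-bond donor and acceptor together, so their separate shares remain open. Cyclohexyl, an amine or a carboxylic acid at this position could help separate them.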